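Shortening one chain on compound 2

This account rests on a few compounds, and the source may have more. Where it says the series, first, only, none or still open, it means among the compounds named here.

In a physicochemical assay for solubility, in phosphate buffer, with a stated time of 18 h, at pH 7.4 (on this read-out lower numbers stand for lower solubility and higher numbers for higher solubility), compound 1 (`COc1ccc(-c2nc(N)n(-c3ncnc4ccccc34)n2)cc1`) gives 5000 nM and compound 3 (`COc1cc2ncnc(-n3nc(-c4ccccn4)cc3N)c2cc1OC`) gives 1000 nM while compound 2 (`COCCOc1cc2ncnc(-n3nc(-c4ccccn4)nc3N)c2cc1OCCOC`) stands highest of the three with 30000 nM as its number. Compound 4 (`COCCOc1cc2c(-n3nc(-c4ccccn4)nc3N)ncnc2cc1OC`) has not been measured yet. It carries hydrogen in place of methoxymethyl on a saturated chain carbon bound to an oxygen on an aromatic ring so that one 2-methoxyethoxy becomes methoxy. Within the data shown here, no measured pair differs in one place only, so the expectation rests on the overall spread. With compound 3 at 1000 nM and compound 1 at 5000 nM as lower numbers, a moderate fall is expected. The estimated change is a 3.0-fold lower number from compound 2 to compound 4 (0.48 log units; beyond the scatter) on this read-out. For compound 4 the estimate is 10000 nM with an expected range from 3000 nM to 30000 nM in this assay terms.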

Compound 4, solubility: 8000 nM
Compound 4: the middle estimate sits 1.3-fold (0.10 log units) above what was measured; the measured number falls inside the stated range.
By their numbers in this assay, from the lowest: compound 3; then compounds 1 and 4 (each within the scatter of the next); then compound 2.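

Among these compounds, this is the first pair that differs in one place only, so one change can be read on its own. In this assay, replacing one 2-methoxyethoxy with methoxy gives a 3.8-fold lower number from compound 2 to compound 4 (0.57 log units; beyond the scatter), a modest step that still shows this chain position affects the number. Nothing available explains why the number moves.

Going by these compounds, it remains open whether shortening the other 2-methoxyethoxy would give a similar step. Also open, on these data alone, is how a longer chain, an amine or a carboxylic acid would read at this position.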